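The source may report more compounds than this note shows. Statements on the series, on what has been measured and on what is new or still open speak of the compounds shown alone.

Of the compounds shown here, three of one shared core have been measured in an assay on T-REx-293 cells for inhibition of potassium channel subfamily T member 1 (Homo sapiens), read by patch clamp; a lower number here means a stronger inhibitor, a higher number a weaker inhibitor. Compound 3 `C[C@H](NC(=O)c1cc(C(F)(F)F)nn1C)c1nc(-c2cccc(F)c2)no1` gives 136 nM, the lowest of the two numbers seen in this assay. Compound 1 `CCc1cc(C(=O)N[C@@H](C)c2nc(-c3cccc(C)c3)no2)n(C)n1` gives 335 nM, a higher number that lies beyond the usual scatter. Compound 2 `Cc1cccc(-c2nnc([C@H](C)NC(=O)c3cc(C4CC4)nn3C)o2)c1` sits at the limit of > 30000 nM in this assay, at which 1 of the 3 values shown sits, a limit and not a number, > 30000 nM. Compound 4 `COc1cc(-c2noc([C@H](C)NC(=O)c3cc(C(F)(F)F)nn3C)n2)cc(C)n1` has not yet been measured; it carries 2-methoxy-6-methylpyridin-4-yl in place of 3-fluorophenyl on an aromatic carbon. Among the compounds with values here, no step of this kind has been measured between any two of the compounds above, so the expected size in this assay rests on compound 3 alone. Compound 4 is expected to keep a number close to that of compound 3, with a step of a 1.1-fold higher number from compound 3 to compound 4 (0.04 log units; within the scatter) that need not exceed the scatter. The estimate for compound 4 is 150 nM, within 40 nM and 600 nM.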

Compound 4, half-maximal inhibitory concentration: 505 nM
The estimate for compound 4 lay 3.4-fold (0.53 log units) below the measured number, and the stated range covers the measured number.
By their numbers in this assay, from the lowest: compound 3; then compounds 1 and 4 (each within the scatter of the next). At a limit, above all of these: compound 2.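

In this assay, putting 2-methoxy-6-methylpyridin-4-yl in place of 3-fluorophenyl gives a 3.7-fold higher number from compound 3 to compound 4 (0.57 log units; beyond the scatter), the first step measured at this position. The position therefore accepts a larger ring that carries a ring nitrogen and two added groups, at a modest cost in inhibition. No measurement shown gives a cause for this rise. Going by these compounds, the ring nitrogen, methoxy and methyl enter together, so their separate shares stay unknown. On these data alone, how a plain pyridine ring, or an amine in place of the methoxy, would read here also stays open.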